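A few compounds are considered here, and "the series" means these few. Any claim that something is new, unique, unknown or untested is made for them only; others in the source may bear on it.

Compound 1, `Cc1ccc(Oc2ccc(/C=N/NC(=S)Nc3ccccc3)cc2)cc1`, in a physicochemical assay for lipophilicity, in phosphate buffer, measured as octanol-water partition, with a stated time of 24 h (a higher number here means a more lipophilic compound, a lower number a more polar compound), gives 5.39.
Compound 2, `Cc1cc(Oc2ccc(/C=N/NC(=S)Nc3ccc(F)cc3)cc2)ccc1Cl`, in this assay gives 6.07.
Compound 3, `S=C(N/N=C/c1ccc(Oc2ccc3ccccc3c2)cc1)Nc1ccc(Cl)cc1`, in this assay gives 6.96.

Among these three, compound 3 has the highest partition coefficient; compound 2 lies nearest to it and compound 1 furthest, and both gaps are beyond the usual scatter of the method. Compound 4, `S=C(N/N=C/c1ccc(Oc2ccc3ccccc3c2)cc1)Nc1ccc(Br)cc1`, has not yet been measured in this assay. It differs from compound 3 in a single place: bromo in place of chloro on an aromatic carbon. Among the measured compounds shown here, no measured pair in this set shows this same exchange, so its effect can only be anticipated. The author expects a small step upward, from compound 3 to compound 4 of about a number 0.19 log units higher from compound 3 to compound 4 (within the scatter), which may not exceed the scatter. Compound 4 is therefore estimated at 7.15, within a range from 6.75 to 7.55.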

Compound 4, partition coefficient: 6.93
Compound 4: middle estimate off by 0.22 log units, on the high side; measured number inside the range.
By their numbers in this assay, from the lowest: compound 1; then compound 2; then compounds 4 and 3 (each within the scatter of the next).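

In this assay, among the compounds shown here, bromo in place of chloro on an aromatic carbon, para to a large group, gives a number 0.03 log units lower from compound 3 to compound 4 (within the scatter) and is the first exchange in this set that can be read at a single place. At this position, then, 4-chlorophenyl and 4-bromophenyl cannot be told apart in this measurement. Nothing available bears on the reason for this result. The compounds shown leave open how an amine or a carboxylic acid at this position would read in this assay. They also leave open whether the same exchange gives a similar step on any other core.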